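The source may report more compounds than this note shows. Statements on the series, on what has been measured and on what is new or still open speak of the compounds shown alone.

Compound 1 `O=S(=O)(Nc1ccc(-c2nc3cc(NS(=O)(=O)c4cccs4)ccc3o2)cc1)c1cccs1` carries a thiophen-2-yl group on each of its two sulfonyl sulfurs, and in an assay on cells for inhibition of HSP60/HSP10 (Homo sapiens), with a stated time of 60 min (a lower number here means a stronger inhibitor, a higher number a weaker inhibitor), compound 1 gives 40000 nM. Compound 2 `O=S(=O)(Nc1ccc(-c2nc3ccccc3o2)cc1)c1cccc(Cl)c1` has a single sulfonamide with a 3-chlorophenyl group on the sulfonyl sulfur; in this assay compound 2 gives 54000 nM. Compound 3 `O=S(=O)(Nc1ccc(-c2nc3ccccc3o2)cc1)c1ccccc1F` differs from compound 2 only by 2-fluorophenyl in place of 3-chlorophenyl on the sulfonyl sulfur. For compound 3 this assay reports a limit rather than a number, > 100000 nM. Compound 3 thus sits at the limit of > 100000 nM in this assay, at which 1 of the 3 values shown sits, the weak end of what is known, although the step of an at least 1.8-fold higher number from compound 2 to compound 3 (0.26 log units; that floor lies within the scatter) stays within the scatter of the measurement.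

Compound 4 `O=S(=O)(Nc1ccc(-c2nc3ccccc3o2)cc1)c1cccs1` arises from compound 3 by thiophen-2-yl in place of 2-fluorophenyl on a sulfonyl sulfur. Among the measured compounds shown here, only one measured step touches this position, the swap of aryl groups from compound 2 to compound 3, and it was too small to read as a real change. Compound 1, which bears thiophen-2-yl on its sulfonyl sulfurs, gives a lower number, but it differs from compound 4 in two places, so its value only hints. A modest move toward stronger inhibition is expected, not clearly beyond the scatter. Compound 4 is estimated at 60000 nM, with a range from 20000 nM to 150000 nM, which means an expected step of an at least 1.6-fold lower number from compound 3 to compound 4 (0.22 log units; that floor lies within the scatter).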

Compound 4, half-maximal inhibitory concentration: 63000 nM
For compound 4 the middle estimate is 1.1-fold (0.02 log units) below the measured one; the range from low to high includes it.
By their numbers in this assay, from the lowest: compounds 1, 2 and 4 (each within the scatter of the next). At a limit, above all of these: compound 3.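

In this assay, thiophen-2-yl on the sulfonyl sulfur gives an at least 1.5-fold lower number from compound 3 to compound 4 (0.20 log units; that floor lies within the scatter). That step can be read only as a floor because compound 3 stands at a limit and not at a number: the limit of > 100000 nM in this assay, at which 1 of the 4 values shown sits. The comparisons with the two measured neighbours add something new, since 3-chlorophenyl and thiophen-2-yl on this sulfur cannot be told apart, with a 1.2-fold higher number from compound 2 to compound 4 (0.07 log units; within the scatter), and the second sulfonamide of compound 1 also makes no difference that can be read, with a 1.6-fold higher number from compound 1 to compound 4 (0.20 log units; within the scatter).

So the three aromatic groups compared at this position, and the added ((thiophen-2-yl)sulfonyl)amino group, give no change beyond the scatter, and the true size of the gap to compound 3 stays unknown while only a limit exists for it. Still open, as far as these compounds go, is whether a group of a different kind on the sulfonyl sulfur, such as a longer carbon chain or a ring bearing an amine or a carboxylic acid, would move the number clearly beyond the scatter.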